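Chloro for hydrogen on the sulfonamide aryl ring, twice

A few compounds are considered here, and "the series" means these few. Any claim that something is new, unique, unknown or untested is made for them only; others in the source may bear on it.

Measured compounds:
compound 1, `CC(=O)OC[C@H]1O[C@@H](n2cc(CN(c3ccccc3)S(=O)(=O)c3ccccc3)nn2)[C@H](OC(C)=O)[C@@H]1OC(C)=O`, 150000 nM
compound 2, `CC(=O)OC[C@H]1O[C@@H](n2cc(CN(c3ccc(Cl)cc3)S(=O)(=O)c3ccccc3)nn2)[C@H](OC(C)=O)[C@@H]1OC(C)=O`, 250000 nM
compound 3, `CCS(=O)(=O)N(Cc1cn([C@@H]2O[C@H](COC(C)=O)[C@@H](OC(C)=O)[C@H](OC(C)=O)[C@H]2OC(C)=O)nn1)c1ccccc1`, 175000 nM

The three measured compounds were examined in a functional assay on RCC4 cells (Homo sapiens) for antiproliferative activity, read by XTT assay, with a stated time of 48 h; on this read-out higher numbers stand for weaker inhibition and lower numbers for stronger inhibition. In this assay compound 1 gives 150000 nM, compound 2 gives 250000 nM and compound 3 gives 175000 nM. All three numbers lie within the scatter of one another, so no order among them can be read from these data.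

Compound 2 differs from compound 1 by the change (chloro in place of hydrogen on an aromatic carbon), and this change made the step of a 1.7-fold higher number from compound 1 to compound 2 (0.22 log units; within the scatter). Compound 4, `CCS(=O)(=O)N(Cc1cn([C@@H]2O[C@H](COC(C)=O)[C@@H](OC(C)=O)[C@H](OC(C)=O)[C@H]2OC(C)=O)nn1)c1ccc(Cl)cc1`, stands to compound 3 as compound 2 stands to compound 1: the difference is chloro in place of hydrogen on an aromatic carbon, at the same place, para to a large group, so it is the same change. The difference between the cores of compound 1 and compound 3 is not broken down here.

Because the earlier change gave only a 1.7-fold higher number from compound 1 to compound 2 (0.22 log units; within the scatter) from compound 1 to compound 2, a step of similar small size is expected from compound 3 to compound 4, namely a 1.5-fold higher number from compound 3 to compound 4 (0.17 log units; within the scatter). On that basis compound 4 is estimated at 260000 nM, with an expected range from 130000 nM to 520000 nM. This rests on a single precedent, so the estimate is held loosely.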

Compound 4, half-maximal inhibitory concentration: > 250000 nM
Compound 4 gave a limit, no number; the forecaster's own chance of this, stated with the estimate: 20%; the middle value lies beyond the limit too.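

In this assay compound 4 gives > 250000 nM, which is a limit of the assay and not a number. Among the compounds shown here, the step on this second core therefore has only a floor, an at least 1.4-fold higher number from compound 3 to compound 4 (0.15 log units; that floor lies within the scatter), and set beside the earlier step it reads: the same change on two cores in this assay, a 1.7-fold higher number (0.22 log units; within the scatter) from compound 1 to compound 2 and an at least 1.4-fold higher number (0.15 log units; that floor lies within the scatter) from compound 3 to compound 4; the limit leaves it open whether they differ What this shows is only that the change from phenyl to 4-chlorophenyl gives no step printed as beyond the scatter on either core; it does not show that the step carries over from one core to the other at the same size, since the true size of the second step is unknown and could be larger than the first.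

The compounds shown leave open what other groups would give at this place on the aromatic ring, such as a methoxy group, an amine or a carboxylic acid, and what a longer chain would give in place of the ethyl group on the sulfonamide. Also open, going by these compounds, is whether a core carrying free hydroxyl groups in place of the acetate esters would let the chloro step be read as a full number in this assay.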